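Aryl Ether Variation in a Spiro Series: Expecting Compound 4

The source may hold more compounds than are shown below. What is called first, only, known or untested is meant among the compounds shown, and "the series" means these compounds.

Compound 1 `NC1=NC2(CCOCC2)N(OCCCOc2ccc(F)cc2)C(N)=N1`: 3280 nM
Compound 2 `Cc1ccc(OCCCON2C(N)=NC(N)=NC23CCOCC3)cc1`: 2390 nM
Compound 3 `NC1=NC2(CCOCC2)N(OCCCOc2ccc(Cl)cc2Cl)C(N)=N1`: 880 nM

Three compounds sharing one core were tested in a functional assay on HCT-116 cells (Homo sapiens) for antiproliferative activity, read by MTT assay, with a stated time of 72 h; on this read-out higher numbers stand for weaker inhibition and lower numbers for stronger inhibition. In this assay compound 3 gives 880 nM, the lowest of the three numbers; compound 2 stands nearest and compound 1 furthest. Two steps lead into the dichlorinated ether: a 3.7-fold lower number from compound 1 to compound 3 (0.57 log units; beyond the scatter) and a 2.7-fold lower number from compound 2 to compound 3 (0.43 log units; beyond the scatter), both beyond the scatter, while a 1.4-fold lower number from compound 1 to compound 2 (0.14 log units; within the scatter) stays within it.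

Compound 4 `COc1ccc(OCCCON2C(N)=NC(N)=NC23CCOCC3)cc1` has not yet been measured. Its change from compound 3 is this: 4-methoxyphenyl in place of 2,4-dichlorophenyl on an oxygen on a saturated carbon. The step to compound 4 reverses the kind of move seen in both informative steps, which ran from a 4-fluorophenyl or a 4-methylphenyl to the 2,4-dichlorophenyl and lowered the number modestly. A modest rise in this assay is therefore expected. Compound 4 is expected to give 2500 nM, within a range of 1200 nM to 6000 nM. That estimate means a step of a 2.8-fold higher number from compound 3 to compound 4 (0.45 log units; beyond the scatter), expected to be beyond the scatter.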

Compound 4, half-maximal inhibitory concentration: 1500 nM
Estimate against measurement, compound 4: 1.7-fold (0.22 log units) above, and the stated range covers the measured number.
By their numbers in this assay, from the lowest: compounds 3, 4, 2 and 1 (each within the scatter of the next, the first and the last beyond it).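

On the aryl group carried on an oxygen on a saturated carbon, compound 4 shows that a ring without chlorine can stay level with the 2,4-dichlorophenyl compound in this assay, as a 1.7-fold higher number from compound 3 to compound 4 (0.23 log units; within the scatter) lies within the scatter, whereas compound 1 and compound 2 both stand beyond it from compound 3. Methoxy and methyl are not separated on the aromatic carbon, with a 1.6-fold lower number from compound 2 to compound 4 (0.20 log units; within the scatter) as the step between them, while methoxy in place of fluoro gives a 2.2-fold lower number from compound 1 to compound 4 (0.34 log units; beyond the scatter) and so stands clear of the scatter. The dichlorinated ring therefore no longer stands apart from every other ring shown, although compound 1 and compound 2 still go against any claim that the rings are interchangeable.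

Nothing measured here gives a reason for these differences. On these data alone, whether an amine or a carboxylic acid on the aromatic ring, or a longer chain in place of the present one, would keep the number near that of compound 3 stays open.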